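From phenyl to oxan-4-yl on a sulfonyl sulfur

This account rests on a few compounds, and the source may have more. Where it says the series, first, only, none or still open, it means among the compounds named here.

In an ADME assay on the whole organism (Rattus norvegicus, strain Harlan-Han Wistar) for metabolic stability (on this read-out higher numbers stand for a longer-lived compound and lower numbers for a shorter-lived compound), compound 1 `Cc1ccc2[nH]c(C(=O)N[C@H]3CN(S(=O)(=O)c4ccccc4)C[C@@H]3C(=O)NCCN(C)C)cc2c1` gives 0.2 h, the lower of the two numbers available. Among the measured compounds shown here, the only other measured compound, compound 2 `Cc1ccc2[nH]c(C(=O)N[C@H]3CN(S(=O)(=O)c4ccnc(C)c4)C[C@@H]3C(=O)NCCN(C)C)cc2c1`, gives 0.8 h and carries 2-methylpyridin-4-yl in place of phenyl on a sulfonyl sulfur. Compound 3 `Cc1ccc2[nH]c(C(=O)N[C@H]3CN(S(=O)(=O)C4CCOCC4)C[C@@H]3C(=O)NCCN(C)C)cc2c1` has not yet been measured in this assay. It carries oxan-4-yl in place of phenyl at that same sulfur: oxan-4-yl in place of phenyl on a sulfonyl sulfur. For the measured compounds named here, no measured step makes this exact change, so compound 2 offers the only guide, through a 4.0-fold higher number from compound 1 to compound 2 (0.60 log units; beyond the scatter), a modest step beyond the scatter. A rise in the same direction is therefore expected, though a smaller one, since the entering group differs. The expected step is a 2.5-fold higher number from compound 1 to compound 3 (0.40 log units; beyond the scatter). For compound 3 the estimated half-life is 0.5 h, with an expected range from 0.2 h to 1.2 h.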

Compound 3, half-life: 0.2 h
Estimate against measurement, compound 3: 2.5-fold (0.40 log units) above; the measured number falls inside the stated range.
By their numbers in this assay, from the lowest: compounds 1 and 3 (each within the scatter of the next); then compound 2.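

Placing oxan-4-yl on the sulfonyl sulfur gives no change at the digits printed from compound 1 to compound 3 (within the scatter) in this assay, so the rise seen with 2-methylpyridin-4-yl does not extend to every replacement of phenyl at this place. Set against 2-methylpyridin-4-yl, the same group gives a 4.0-fold lower number from compound 2 to compound 3 (0.60 log units; beyond the scatter), leaving compound 2 as the only one of the three whose number stands apart from the others. Nothing available here explains this difference between the two entering groups.

As far as these compounds go, it remains open whether the ring nitrogen or the methyl group of 2-methylpyridin-4-yl goes with the longer half-life, a question that unsubstituted pyridin-4-yl and a methylphenyl group on the sulfonyl sulfur could separate. From the compounds shown here alone, how an amine or a carboxylic acid on the entering ring would read in this assay also remains open.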